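The compounds below may be only part of what the source reports. "The series", "measured", "known", "first", "only" and "open" are said of these compounds alone.

Compound 1, `COc1cc2ncnc(Nc3cccc(F)c3)c2cc1OCCCN1CCNCCNCCNCC1`, gives in a functional assay on A549 cells (Homo sapiens) for antiproliferative activity, read by MTT assay, with a stated time of 72 h (a higher number here means a weaker inhibitor, a lower number a stronger inhibitor), only a limit, > 50000 nM.
Compound 2, `COc1cc2ncnc(Nc3cccc(I)c3)c2cc1OCCCN1CCNCCNCCNCC1`, gives in this assay 14500 nM.
Compound 3, `COc1cc2ncnc(Nc3cccc(F)c3)c2cc1OCCCN1CCNCCNCC1`, gives in this assay only a limit, > 50000 nM.

Compound 1 and compound 2 share one core and differ in a single place: iodo in place of fluoro on an aromatic carbon. That change brings an at least 3.4-fold lower number from compound 1 to compound 2 (0.53 log units; beyond the scatter), so the iodo compound is the stronger inhibitor of the pair, although the true size of the step is hidden because the value of compound 1 is a limit.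

Compound 3 carries a different core. Its difference from compound 1 is a group of 9 heavy atoms (6 carbon, 3 nitrogen; one nine-membered non-aromatic ring with 3 hetero atoms) in place of a group of 12 heavy atoms (8 carbon, 4 nitrogen; one twelve-membered non-aromatic ring with 4 hetero atoms), on a saturated chain carbon, three bonds along the chain from an oxygen on an aromatic ring. The step that the two limits leave unreadable from compound 1 to compound 3 cannot be sized because of the limit of > 50000 nM in this assay, at which 2 of the 3 values shown sit.

The unmeasured compound 4, `COc1cc2ncnc(Nc3cccc(I)c3)c2cc1OCCCN1CCNCCNCC1`, stands to compound 3 as compound 2 stands to compound 1. The change is iodo in place of fluoro on an aromatic carbon, the same change at the same place on a core that differs only in the ring at the end of the chain. Since compound 3 sits at a limit, as compound 1 does, the expected step is an at least 2.5-fold lower number from compound 3 to compound 4 (0.39 log units; beyond the scatter), resting on the measured pair where the same change gave an at least 3.4-fold lower number from compound 1 to compound 2 (0.53 log units; beyond the scatter). Compound 4 is therefore expected to reach about 20000 nM in this assay, likely between 8000 nM and 60000 nM, with a fair chance that only a limit is reported again.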

Compound 4, half-maximal inhibitory concentration: 26200 nM
Compound 4: middle estimate off by 1.3-fold (0.12 log units), on the low side; the measured number falls inside the stated range.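

In this assay the change from 3-fluorophenyl to 3-iodophenyl, carried over to the core with the nine-membered ring, gives an at least 1.9-fold lower number from compound 3 to compound 4 (0.28 log units; that floor lies within the scatter), and beside the earlier pair the two steps read: the same change on two cores in this assay, an at least 3.4-fold lower number (0.53 log units; beyond the scatter) from compound 1 to compound 2 and an at least 1.9-fold lower number (0.28 log units; that floor lies within the scatter) from compound 3 to compound 4; the limit leaves it open whether they differ

Both iodo compounds give a number where both fluoro compounds sit at a limit, so the result fits the same direction on the two cores, and with iodo in place, the swap of the larger ring for the nine-membered ring gives a 1.8-fold higher number from compound 2 to compound 4 (0.26 log units; within the scatter). What this does not show is that the size of the step carries over from one core to the other, and the step between the two fluoro compounds cannot be read either, because of the limit: the limit of > 50000 nM in this assay, at which 2 of the 4 values shown sit.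

The compounds shown leave open how chloro or bromo would read in place of iodo on the same aromatic carbon. They also leave open whether a longer chain, or an open-chain amine in place of the ring, would move the number in this assay.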